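A few compounds are considered here, and "the series" means these few. Any claim that something is new, unique, unknown or untested is made for them only; others in the source may bear on it.

Measured compounds:
- compound 1, `CCOC(=O)[C@]1(C)C[C@@H](C)C=[N+]1[O-]`, 1.67 in a physicochemical assay for lipophilicity; on this read-out higher numbers stand for higher lipophilicity and lower numbers for lower lipophilicity
- compound 2, `CCOC(=O)[C@@]1(CC)C[C@H](C)C=[N+]1[O-]`, 1.48 in this assay

Compound 1 and compound 2 share the same core and differ in the group on the ring carbon bearing the ester. In this assay compound 1 gives 1.67 and compound 2 gives 1.48; the gap between them lies within the usual scatter of repeated measurements, so the two values cannot be told apart.

Compound 3, `CCOC(=O)[C@@]1(CC)C[C@@H](C)C=[N+]1[O-]`, is not yet measured. Compared with compound 2, the change is as follows: the two compounds have the same atoms and bonds and differ only in configuration as drawn: 1 of 2 stereo elements differ; a stereocentre at a saturated ring carbon is drawn S in compound 2 and R in compound 3. No atom leaves and none enters, only the drawn configuration at one ring carbon is different.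

Among the measured compounds shown here, no measured pair here shows the effect of such a change in configuration alone. For a pair that is otherwise identical in atoms and bonds, a step within the scatter is expected in this assay, in no particular direction. Compound 3 is therefore estimated at 1.48, with a range from 1.18 to 1.78, which means an expected step of no change at the digits printed from compound 2 to compound 3 (within the scatter).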

Compound 3, partition coefficient: 1.34
Beside the measured number, compound 3's estimate is 0.14 log units above it; the range from low to high includes it.
By their numbers in this assay, from the lowest: compounds 3, 2 and 1 (each within the scatter of the next, the first and the last beyond it).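

Among the compounds shown here, a change of configuration alone, at one saturated ring carbon drawn S and then R, can now be read directly for the first time: in this assay it gives a number 0.14 log units lower from compound 2 to compound 3 (within the scatter). On this single pair, then, swapping the drawn configuration at this carbon leaves no difference that can be separated from the ordinary spread of repeat measurements. The comparison is a clean one because nothing else separates the pair: the fact that compounds 2 and 3 differ only in the configuration as drawn

The compounds shown leave open whether the same swap would also stay within the scatter with the smaller group of compound 1 on the ring carbon bearing the ester, or at the other stereocentre. They also leave open what a carboxylic acid in place of the ester, or a longer chain on that carbon, would give in this assay.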